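A Fluorine Added to the Phenylsulfonyl Ring

This account rests on a few compounds, and the source may have more. Where it says the series, first, only, none or still open, it means among the compounds named here.

Measured so far:
Compound 1 `COc1ccc(Nc2nc3ccccc3nc2S(=O)(=O)c2ccccc2)cc1`: 11900 nM
Compound 2 `Nc1ccc(Nc2nc3ccccc3nc2S(=O)(=O)c2ccccc2)cc1`: 12900 nM
Compound 3 `O=S(=O)(c1ccccc1)c1nc2ccccc2nc1Nc1ccc(C(F)(F)F)cc1`: > 50000 nM (a limit of the assay)

Of the compounds shown here, three sharing one core have been tested in a functional assay on A549 cells (Homo sapiens) for cytotoxicity, read by MTT assay, with a stated time of 72 h; a lower number here means a stronger inhibitor, a higher number a weaker inhibitor. In this assay compound 1 gives 11900 nM. Compound 2 gives 12900 nM, and the change between them is a 1.1-fold higher number from compound 1 to compound 2 (0.04 log units; within the scatter). For compound 3 only a limit of the assay is reported, > 50000 nM. The steps to it are an at least 4.2-fold higher number from compound 1 to compound 3 (0.62 log units; beyond the scatter) and an at least 3.8-fold higher number from compound 2 to compound 3 (0.58 log units; beyond the scatter). Compound 1 thus holds the lowest of the two actual numbers, with compound 2 sitting within the scatter of it, and compound 3 known only as a limit, as stated in the limit of > 50000 nM in this assay, at which 1 of the 3 values shown sits.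

Compound 4 `COc1ccc(Nc2nc3ccccc3nc2S(=O)(=O)c2ccc(F)cc2)cc1` is not yet measured. Compared with compound 1 the change is fluoro in place of hydrogen on an aromatic carbon. Every measured step alters the group on the aniline ring and leaves the phenylsulfonyl ring untouched, so none bears directly on this change. The change is a single small atom on a ring that the measured steps never varied, and the expectation is no step beyond the scatter: a 1.0-fold higher number from compound 1 to compound 4 (0.00 log units; within the scatter). Compound 4 is therefore estimated at 12000 nM, expected within the range 5000 nM to 30000 nM.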

Compound 4, half-maximal inhibitory concentration: 4840 nM
Beside the measured number, compound 4's estimate is 2.5-fold (0.39 log units) above it, outside the stated range (below it).
By their numbers in this assay, from the lowest: compound 4; then compounds 1 and 2 (each within the scatter of the next). At a limit, above all of these: compound 3.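

In this assay the phenylsulfonyl ring proves able to move the result: phenyl to 4-fluorophenyl, with the fluoro para to a large group, gives a 2.5-fold lower number from compound 1 to compound 4 (0.39 log units; beyond the scatter) and so lies beyond the usual scatter. Going by these compounds alone, until now only the group on the aniline ring had been varied, so this is the first sign that the other ring also matters and that one added heavy atom there is enough to shift the number, though the step is modest in size. Nothing measured here explains why this one atom lowers the number.

Only fluoro has been shown on this ring, so it remains open whether chloro, methyl, methoxy or a nitrile at the same place would give a similar step, and whether fluoro would do the same at another place on the ring. Going by these compounds, it is also open whether the step carries over to a compound with a different aniline group, such as the amino group of compound 2, since fluoro appears here only with methoxy on that ring.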